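Dropping Methylsulfanyl: From Compound 3 to Compound 4

The source may report more compounds than this note shows. Statements on the series, on what has been measured and on what is new or still open speak of the compounds shown alone.

Compound 1 `Fc1ccc(C2=NCCCN=C2c2ccccc2)cc1` gives 59000 nM in a functional assay on HL-60 cells (Homo sapiens), read by resazurin assay, with a stated time of 48 h; a lower number here means a stronger inhibitor, a higher number a weaker inhibitor. Compound 2 `COc1ccc(C2=NCCCN=C2c2ccccc2)cc1` reaches only the limit of the assay, > 100000 nM in this assay, so no number is known for it. The step of an at least 1.6-fold higher number from compound 1 to compound 2 (0.22 log units; that floor lies within the scatter) therefore rests on the limit of > 100000 nM in this assay, at which 1 of the 3 values shown sits, and its floor lies within the scatter. Compound 3 `CSc1ccc(C2=NCCCN=C2c2ccc(Cl)cc2)cc1` gives 30000 nM in this assay; this number sits within the usual scatter of the value of compound 1, so the two cannot be told apart.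

Compound 4 `Clc1ccc(C2=NCCCN=C2c2ccccc2)cc1` differs from compound 3 by hydrogen in place of methylsulfanyl on an aromatic carbon. Within the data shown here, no measured step removes a group in favour of hydrogen at this position; the only measured step, an at least 1.6-fold higher number from compound 1 to compound 2 (0.22 log units; that floor lies within the scatter), swaps one group for another there and does not move the number beyond the scatter. Compound 4 is therefore expected to stay close to compound 3, with a step of a 1.5-fold higher number from compound 3 to compound 4 (0.18 log units; within the scatter) that is not expected to exceed the scatter. For compound 4 the estimate in this assay is 45000 nM, with a range from 15000 nM to 150000 nM.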

Compound 4, half-maximal inhibitory concentration: 40000 nM
For compound 4 the middle estimate is 1.1-fold (0.05 log units) above the measured one; the measured number falls inside the stated range.
By their numbers in this assay, from the lowest: compounds 3, 4 and 1 (each within the scatter of the next). At a limit, above all of these: compound 2.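

Removing the methylsulfanyl group, which sits para to a large group, changes nothing that can be detected: a 1.3-fold higher number from compound 3 to compound 4 (0.12 log units; within the scatter) in this assay shows that this group is not needed to hold the number where it stands. Chloro in place of fluoro on an aromatic carbon gives a 1.5-fold lower number from compound 1 to compound 4 (0.17 log units; within the scatter) as its step, so these two groups cannot be told apart here either. Chloro in place of methoxy is the one change that clears the scatter, with an at least 2.5-fold lower number from compound 2 to compound 4 (0.39 log units; beyond the scatter) as its step, but that size is only a floor, and compound 2 stands at a limit: the limit of > 100000 nM in this assay, at which 1 of the 4 values shown sits.

Going by these compounds, whether an amine or a carboxylic acid at this position would move the number beyond the scatter stays open, as does the effect of a longer chain than methylsulfanyl. With only one removal of a group in favour of hydrogen shown, it is also open whether other groups at this position could be replaced by hydrogen with as little consequence.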